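A few compounds are considered here, and "the series" means these few. Any claim that something is new, unique, unknown or untested is made for them only; others in the source may bear on it.

Compound 1: `COCCOC(=O)c1cc(N)c(Nc2ccc(C#N)cc2)cc1Oc1c(C)cc(/C=C/C#N)cc1C` — 0.158 h
Compound 2: `Cc1cc(/C=C/C#N)cc(C)c1Oc1cc(Nc2ccc(C#N)cc2)c(N)cc1C(=O)NN` — 0.65 h

Both numbers come from an ADME assay on liver (Homo sapiens) for metabolic stability, read by LC-MS, using S9 fraction and NADPH, with a stated time of 45 min, tested at 1 uM; on this read-out lower numbers stand for a shorter-lived compound and higher numbers for a longer-lived compound. Within the data shown here, compound 2 stands highest of the two, with compound 1 as its only neighbour, and the single measured step, a 4.1-fold higher number from compound 1 to compound 2 (0.61 log units; beyond the scatter), separates them.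

Compound 3, `Cc1cc(/C=C/C#N)cc(C)c1Oc1cc(Nc2ccc(C#N)cc2)c(N)cc1C(=O)N1CC1`, is reached from compound 2 by one change: aziridin-1-yl in place of aminoamino on a carbonyl carbon. The group that leaves here is the very group that entered in the step from compound 1 to compound 2, so that step is the one that bears on the present case, yet only in part: neither of its two groups is the one that now enters, and nothing measured shows what an aziridin-1-yl on this carbonyl carbon does in this assay. With a sole step of modest size as guide, and its direction set by a group that is now removed, the expectation is for a step from compound 2 to compound 3 that runs the other way but stays close to the scatter, estimated as a 1.6-fold lower number from compound 2 to compound 3 (0.21 log units; within the scatter). For compound 3 the expected half-life in this assay is 0.4 h, within a range of 0.15 h to 1.1 h.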

Compound 3, half-life: 1.83 h
For compound 3 the middle estimate is 4.6-fold (0.66 log units) below the measured one; measured number outside the range, above it.
By their numbers in this assay, from the lowest: compound 1; then compound 2; then compound 3.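

In this assay, the group on the carbonyl carbon whose other neighbour is an aromatic carbon still has room to raise the half-life after the first change: aziridin-1-yl in place of aminoamino gives a 2.8-fold higher number from compound 2 to compound 3 (0.45 log units; beyond the scatter), a step beyond the scatter that runs the same way as a 4.1-fold higher number from compound 1 to compound 2 (0.61 log units; beyond the scatter). Against the 2-methoxyethoxy ester the change adds up to a 12-fold higher number from compound 1 to compound 3 (1.06 log units; beyond the scatter), the only large step among these compounds, and it shows that the hydrogen-bond donors counted on aminoamino are not required for the longest half-life seen here, since aziridin-1-yl carries none. Nothing measured here speaks to the reason for this rise.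

The compounds shown leave open whether the result depends on the three-membered ring itself or holds for any group on this carbonyl carbon without those donors, a question that azetidin-1-yl, pyrrolidin-1-yl or dimethylamino in the same place would bear on. They also leave open how a simple unsubstituted amino group or a hydroxyl, which would make a carboxylic acid, would stand on this carbonyl carbon.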